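From a carboxy end to a two-ring group

The source may hold more compounds than are shown below. What is called first, only, known or untested is meant among the compounds shown, and "the series" means these compounds.

In a functional assay on MCF7 cells (Homo sapiens) for antiproliferative activity, read by luminescence, with a stated time of 24 h (a lower number here means a stronger inhibitor, a higher number a weaker inhibitor), compound 1 (`Cc1cc(C)c2c(c1C)OC(C)(COc1ccc(/C=C3\SC(=O)NC3=O)cc1)CC2`) gives 12500 nM as a measured number. For compound 2 (`Cc1c(C)c2c(c(C)c1OC(=O)CCC(=O)O)CCC(C)(COc1ccc(CC3SC(=O)NC3=O)cc1)O2`) the reading is > 50000 nM, which is a limit of the assay and not a number. Going by these compounds, compound 2 therefore stands at the limit, and its true value is unknown.

Compound 3 (`Cc1c(C)c2c(c(C)c1OC(=O)CCCC[C@@H]1SC[C@@H]3NC(=O)N[C@@H]31)CCC(C)(COc1ccc(CC3SC(=O)NC3=O)cc1)O2`) differs from compound 2 at one place. The change is as follows: a group of 11 heavy atoms (7 carbon, 2 nitrogen, 1 oxygen, 1 sulfur; one five-membered non-aromatic ring with 1 hetero atom, one five-membered non-aromatic ring with 2 hetero atoms) in place of a group of 3 heavy atoms (1 carbon, 2 oxygen; no ring), on a saturated chain carbon, two bonds along the chain from a carbonyl carbon. The carboxy leaves, and the group that enters holds one five-membered non-aromatic ring with 1 hetero atom and one with 2 hetero atoms.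

Going by the values given here, no measured step shows what such a replacement does in this assay, so only a modest shift toward stronger inhibition is expected, and compound 3 may well stay at the limit. Compound 1 at 12500 nM is the reason to expect that a measurable number remains possible. The expected change is an at least 1.4-fold lower number from compound 2 to compound 3 (0.15 log units; that floor lies within the scatter), an estimate with wide uncertainty. For compound 3 the estimate is 35000 nM, with an expected range from 10000 nM to 100000 nM as the reading.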

Compound 3, half-maximal inhibitory concentration: 15900 nM
Beside the measured number, compound 3's estimate is 2.2-fold (0.34 log units) above it, within the range that was stated.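

Going by these compounds alone, the replacement of the carboxy by the two-ring group, on a saturated chain carbon, two bonds along the chain from a carbonyl carbon, gives the first readable step at this position: this assay shows an at least 3.1-fold lower number from compound 2 to compound 3 (0.49 log units; beyond the scatter). Swapping the small acid end for this much larger group, with its two five-membered non-aromatic rings, therefore does not cost activity here, and compound 3 gives a measured number of 15900 nM, so the chain end accepts a large ring-bearing group. The step is only a floor, and its true size stays unknown, because the reading of compound 2 is a limit of the assay and not a number: the limit of > 50000 nM in this assay, at which 1 of the 3 values shown sits.

This single pair cannot separate the effect of losing the carboxy from the effect of what enters, and a simple methyl group or a plain longer chain at the same place would be needed to tell these apart. Going by these compounds, it also remains open whether the ring system as a whole is needed or a single ring would do, and whether an amine at this chain end would give a similar reading.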